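Trifluoromethyl in Place of Cyano: Little Shift Expected

This account rests on a few compounds, and the source may have more. Where it says the series, first, only, none or still open, it means among the compounds named here.

Three measured compounds share one core and differ only in the six-membered aromatic ring of carbon only on the amide-type nitrogen. In an assay on HEK cells for inhibition of Tryptophan 2,3-dioxygenase (Homo sapiens) (a lower number here means a stronger inhibitor, a higher number a weaker inhibitor), compound 1 `O=C(Nc1ccc(Cl)cc1)C(=O)N1CCC(c2ccnc3ccc(F)cc23)CC1` gives 6900 nM, compound 2 `O=C(Nc1ccc(Cl)cc1F)C(=O)N1CCC(c2ccnc3ccc(F)cc23)CC1` gives 6700 nM, and compound 3 `N#Cc1ccc(NC(=O)C(=O)N2CCC(c3ccnc4ccc(F)cc34)CC2)cc1` gives 5500 nM. Compound 3 shows the lowest of the three numbers, yet its separations from the others, a 1.3-fold lower number from compound 1 to compound 3 (0.10 log units; within the scatter) and a 1.2-fold lower number from compound 2 to compound 3 (0.09 log units; within the scatter), both lie within the scatter, so the three stand level. Compound 4 `O=C(Nc1ccc(C(F)(F)F)cc1)C(=O)N1CCC(c2ccnc3ccc(F)cc23)CC1` carries trifluoromethyl in place of cyano on an aromatic carbon. Within the data shown here, no measured step involves trifluoromethyl; the closest guides are the cyano-for-chloro swap, a 1.3-fold lower number from compound 1 to compound 3 (0.10 log units; within the scatter), and the added fluoro, a 1.0-fold lower number from compound 1 to compound 2 (0.01 log units; within the scatter), both within the scatter. Compound 4 is therefore expected to show a step of a 1.1-fold higher number from compound 3 to compound 4 (0.04 log units; within the scatter), nothing beyond the scatter. Compound 4 is estimated at 6000 nM, between 3000 nM and 12000 nM.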

Compound 4, half-maximal inhibitory concentration: 9500 nM
Compound 4: the middle estimate sits 1.6-fold (0.20 log units) below what was measured; the measured number falls inside the stated range.
By their numbers in this assay, from the lowest: compounds 3, 2, 1 and 4 (each within the scatter of the next).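

Trifluoromethyl, which brings more heavy atoms than cyano, is accepted at this position on the ring in this assay with no step beyond the scatter, whether it replaces cyano (a 1.7-fold higher number from compound 3 to compound 4 (0.24 log units; within the scatter)), chloro (a 1.4-fold higher number from compound 1 to compound 4 (0.14 log units; within the scatter)) or the 4-chloro-2-fluorophenyl pattern (a 1.4-fold higher number from compound 2 to compound 4 (0.15 log units; within the scatter)). All four compounds therefore stand level, so this position has not yet shown any sensitivity to the group it carries. Nothing available explains this flat result. Still open, on these data alone, is whether an amine or a carboxylic acid at this position would shift the number beyond the scatter.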